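The source may hold more compounds than are shown below. What is called first, only, known or untested is meant among the compounds shown, and "the series" means these compounds.

Of the compounds shown here, two with a shared core have been measured. For the measured compounds named here, compound 1 `CCNC(=O)c1cc(Oc2ccc(NC(=O)c3cc4cccnc4n(-c4ccccc4F)c3=O)cc2)ccn1` gives 490 nM in a functional assay on A549 cells (Homo sapiens) for antiproliferative activity, read by MTT assay, with a stated time of 72 h (on this read-out lower numbers stand for stronger inhibition and higher numbers for weaker inhibition), while compound 2 `CCNC(=O)c1cc(Oc2ccc(NC(=O)c3cc4cccnc4n(-c4ccc(C(F)(F)F)cc4Cl)c3=O)cc2)ccn1` gives 3290 nM; the only step between them, a 6.7-fold higher number from compound 1 to compound 2 (0.83 log units; beyond the scatter), concerns the aromatic group on the ring nitrogen. Compound 2 therefore stands at the higher of the two numbers seen so far, with compound 1 the nearer and lower one.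

Compound 3 `CCCNC(=O)c1cc(Oc2ccc(NC(=O)c3cc4cccnc4n(-c4ccc(C(F)(F)F)cc4Cl)c3=O)cc2)ccn1` differs from compound 2 by methyl in place of hydrogen on a saturated chain carbon, two bonds along the chain from an amide-type nitrogen. Going by the values given here, no measured step touches this part of the molecule: the one step known changes the aryl group, not the amide side chain, so it offers no guide to the direction here. Given that absence, the expected step of a 1.0-fold higher number from compound 2 to compound 3 (0.00 log units; within the scatter) is none beyond the scatter. On this basis compound 3 is estimated at 3300 nM, within a range from 1400 nM to 7500 nM.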

Compound 3, half-maximal inhibitory concentration: 1250 nM
Beside the measured number, compound 3's estimate is 2.6-fold (0.42 log units) above it, and the stated range ends above it.
By their numbers in this assay, from the lowest: compound 1; then compound 3; then compound 2.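

The amide side chain proves responsive: in this assay, the change from ethylamino to propylamino gives a 2.6-fold lower number from compound 2 to compound 3 (0.42 log units; beyond the scatter) and so moves the number beyond the scatter with one added methyl on a saturated chain carbon, two bonds along the chain from an amide-type nitrogen. For the compounds shown here, this is the first step read at this position, and it runs towards stronger inhibition, whereas the earlier step concerned only the aromatic group on the ring nitrogen. Nothing available explains why the added methyl has this effect.

As far as these compounds go, whether the trend continues to a longer chain such as butyl, or survives a hydroxyl or an amine at the chain end, remains open. Also open, from the compounds shown here alone, is whether ethyl to propyl would act the same way with the 2-fluorophenyl group of compound 1 on the ring nitrogen.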